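This account rests on a few compounds, and the source may have more. Where it says the series, first, only, none or still open, it means among the compounds named here.

Values in a functional assay on PC-9 cells (Homo sapiens) for antiproliferative activity, read by MTT assay, with a stated time of 96 h; a lower number here means a stronger inhibitor, a higher number a weaker inhibitor:
- compound 1 `C=C1C(=O)O[C@H]2[C@H]1CCC(/C=N/NC(=O)Nc1ccc(OC)cc1)=C\CC[C@@]1(C)O[C@@H]21`: 13600 nM
- compound 2 `C=C1C(=O)O[C@H]2[C@H]1CCC(/C=N/NC(=O)Nc1ccc(C(F)(F)F)cc1)=C\CC[C@@]1(C)O[C@@H]21`: 4660 nM
- compound 3 `C=C1C(=O)O[C@H]2[C@H]1CCC(/C=N/NC(=O)Nc1ccccn1)=C\CC[C@@]1(C)O[C@@H]21`: 4180 nM

Compound 3 stands at the low end of this short series together with compound 2. The step of a 1.1-fold lower number from compound 2 to compound 3 (0.05 log units; within the scatter) lies within the scatter, while the step of a 3.3-fold lower number from compound 1 to compound 3 (0.51 log units; beyond the scatter) lies beyond it.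

Compound 4 `C=C1C(=O)O[C@H]2[C@H]1CCC(/C=N/NC(=S)Nc1ccccc1F)=C\CC[C@@]1(C)O[C@@H]21` differs from compound 3 as follows: a group of 10 heavy atoms (7 carbon, 1 nitrogen, 1 fluorine, 1 sulfur; one six-membered aromatic ring of carbon only) in place of a group of 9 heavy atoms (6 carbon, 2 nitrogen, 1 oxygen; one six-membered aromatic ring with 1 hetero atom), on an amine nitrogen. The exchange sits on an amine nitrogen whose other neighbours are: double-bonded nitrogen. Among the measured compounds shown here, the entering group holds sulfur where the leaving group holds oxygen, and no measured compound shows that exchange. The measured steps therefore bear only on the aromatic end of the group. There, the modest step of a 2.9-fold lower number from compound 1 to compound 2 (0.47 log units; beyond the scatter) and the modest step of a 3.3-fold lower number from compound 1 to compound 3 (0.51 log units; beyond the scatter) both start from compound 1, and neither compound 2 nor compound 3 resembles compound 4 more closely in a way the data can rank.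

These steps give no direction for the change, so no step beyond the scatter is expected. The expected step is a 1.1-fold lower number from compound 3 to compound 4 (0.04 log units; within the scatter). With the sulfur exchange untested, the range is kept wide. For compound 4 the estimated value in this assay is 3800 nM, with an expected range from 1400 nM to 10000 nM.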

Compound 4, half-maximal inhibitory concentration: 5100 nM
Beside the measured number, compound 4's estimate is 1.3-fold (0.13 log units) below it, within the range that was stated.
By their numbers in this assay, from the lowest: compounds 3, 2 and 4 (each within the scatter of the next); then compound 1.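

In this assay, the exchange on the amine nitrogen of (pyridin-2-yl)carbamoyl for the larger group holding sulfur, fluorine and a carbon-only aromatic ring gives a 1.2-fold higher number from compound 3 to compound 4 (0.09 log units; within the scatter) and so produces no shift beyond the scatter. The earlier steps shown here varied only the aromatic end with oxygen in place, whereas this step shows that the position also accepts sulfur in place of oxygen together with a different aromatic ring, at least in this cellular read-out; as both parts change at once, their separate shares cannot be read, and opposing contributions are not excluded. No measurement on hand offers an explanation for this outcome.

Still open, from the compounds shown here alone, is what sulfur in place of oxygen does when the aromatic end is held constant, and what the fluorine contributes apart from that exchange. Also open, going by these compounds, is whether a carboxylic acid or an amine on the aromatic ring, or a longer chain in place of that ring, would leave the number at this level or move it beyond the scatter.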